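Hydrazide to dimethylamide on the shared core

The source may hold more compounds than are shown below. What is called first, only, known or untested is meant among the compounds shown, and "the series" means these compounds.

For the measured compounds named here, compound 1 `COc1cccc(-c2nc(SC)nc3sc(C(=O)NNC(C)(C)C)c(N)c23)c1` is the weaker of the two compounds measured so far in a functional assay on HEK293 cells for agonist activity at lutropin-choriogonadotropic hormone receptor (Homo sapiens), read by cAMP accumulation; a higher number here means a larger maximal response, a lower number a smaller maximal response: compound 1 reaches 6%. Going by the values given here, compound 2 `COc1cccc(-c2nc(SC)nc3sc(C(=O)NC(C)(C)C)c(N)c23)c1OC` differs from compound 1 in two places at once, so no single step between them is counted; in this assay compound 2 gives 50.1%, a gap that lies beyond the usual scatter. The only sign from the measured pair is that a tert-butyl amide on the shared core can be paired with a clearly larger maximal response than the tert-butyl hydrazide of compound 1, though the methoxy pattern on the phenyl ring moves as well.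

Compound 3 `COc1cccc(-c2nc(SC)nc3sc(C(=O)N(C)C)c(N)c23)c1` has not yet been tested. It differs from compound 1 by dimethylamino in place of ((tert-butyl)amino)amino on a carbonyl carbon. Nothing measured here isolates that change, so the expectation is loose. The step is expected to run upward and beyond the scatter, a number 24 percentage points higher from compound 1 to compound 3 (beyond the scatter), since compound 2 shows that an amide on this carbonyl carbon goes with 50.1%. For compound 3 the expected maximal response in this assay is 30%, within a range of 5% to 65%.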

Compound 3, largest response reached (reported as efficacy), in percent of the reference or control that the assay uses: 11%
Estimate against measurement, compound 3: 19 percentage points above; measured number inside the range.
By their numbers in this assay, from the lowest: compounds 1 and 3 (each within the scatter of the next); then compound 2.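

For the compounds shown here, at the carbonyl carbon of the shared core, in this assay the exchange of ((tert-butyl)amino)amino for dimethylamino gives a number 5 percentage points higher from compound 1 to compound 3 (within the scatter) and is the first change that can be read in one place. A group of 6 heavy atoms with 2 hydrogen-bond donors can thus give way to one of 3 heavy atoms with 0 hydrogen-bond donors with no change beyond the scatter in the maximal response. A dimethylamide on this carbonyl carbon therefore does not by itself go with a large maximal response, and compound 2 differs from compound 1 and from compound 3 in more than one place, so its steps cannot be read and its value cannot be assigned to its amide or to its methoxy pattern.

No measurement shown gives a reason for this result. Still open, from the compounds shown here alone, is whether a tert-butyl amide on the exact core of compound 1 would raise the maximal response, and whether a morpholine amide or a carboxylic acid on this carbonyl carbon would depart from compound 1 and compound 3.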